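The source may report more compounds than this note shows. Statements on the series, on what has been measured and on what is new or still open speak of the compounds shown alone.

Compound 3 `COc1ccc(/C=N/n2c(SC)nnc2-c2cc(OC)c(OC)c(OC)c2)c(OC)c1` is one of three compounds examined in a functional assay on HepG2 cells (Homo sapiens) for cytotoxicity, read by MTT assay, with a stated time of 48 h; on this read-out higher numbers stand for weaker inhibition and lower numbers for stronger inhibition. In this assay compound 3 gives only a limit, > 200000 nM. Compound 1 `COc1cc(-c2nnc(SC)n2/N=C/c2ccccc2)cc(OC)c1OC` likewise gives a limit, > 200000 nM. Compound 2 `COc1cc(-c2nnc(SCc3ccccc3)n2/N=C/c2ccccc2)cc(OC)c1OC` also gives a limit, > 200000 nM. The step that the two limits leave unreadable from compound 1 to compound 3 cannot be read, and neither can a step that the two limits leave unreadable from compound 1 to compound 2, since all three values sit at the limit of > 200000 nM in this assay, at which 3 of the 3 values shown sit. Compound 4 `COc1ccc(/C=N/n2c(SCc3ccccc3Cl)nnc2-c2cc(OC)c(OC)c(OC)c2)c(OC)c1` differs from compound 3 by 2-chlorophenyl in place of hydrogen on a saturated chain carbon bound to a sulfur. The closest measured counterpart of this change, a step that the two limits leave unreadable from compound 1 to compound 2, yields no readable size, so no direction can be drawn from it. Compound 4 is expected to remain at the limit as well, with an estimated step that the limit leaves unreadable from compound 3 to compound 4. The estimate for compound 4 is 250000 nM, within a range of 80000 nM to 1000000 nM.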

Compound 4, half-maximal inhibitory concentration: > 200000 nM
Compound 4: no number, only a limit; the forecaster's own chance of this, stated with the estimate: 80%; the middle value is on the limit's open side.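

No step from compound 3 to compound 4 can be read, as both values are limits and not numbers: the limit of > 200000 nM in this assay, at which 4 of the 4 values shown sit.

The compounds shown leave open whether any of these changes affects cytotoxicity, and at what concentration any of the four would act.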